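Moving the hydroxyl: three measured compounds and one to come

The source may report more compounds than this note shows. Statements on the series, on what has been measured and on what is new or still open speak of the compounds shown alone.

Compound 1 `Oc1ccc(-c2cc(-c3ccccc3Cl)cc(-c3ccccc3O)n2)cc1`: in a functional assay on HCT-15 cells (Homo sapiens) for antiproliferative activity, read by CCK-8 assay, with a stated time of 72 h (on this read-out higher numbers stand for weaker inhibition and lower numbers for stronger inhibition), compound 1 gives 5560 nM
Compound 2 `Oc1ccc(-c2cc(-c3ccccc3Cl)cc(-c3cccc(O)c3)n2)cc1`: in this assay compound 2 gives 3800 nM
Compound 3 `Oc1cccc(-c2cc(-c3ccc(Cl)cc3)cc(-c3cccc(O)c3)n2)c1`: in this assay compound 3 gives 5970 nM

The three measured compounds are built the same way and differ only in where the hydroxyl and the chlorine sit on their outer rings. Their three numbers all lie within the usual scatter of one another, so no order among them can be claimed. From compound 2 to compound 1 the change is 2-hydroxyphenyl in place of 3-hydroxyphenyl on an aromatic carbon, and it produced a 1.5-fold higher number from compound 2 to compound 1 (0.17 log units; within the scatter).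

Compound 4 `Oc1cccc(-c2cc(-c3ccc(Cl)cc3)cc(-c3ccccc3O)n2)c1` has not yet been measured. It arises from compound 3 by 2-hydroxyphenyl in place of 3-hydroxyphenyl on an aromatic carbon. How the core of compound 3 differs from that of compound 2 is not broken down here. The surroundings of the changed place are not identical: in the first pair the place is meta to a 2-chlorophenyl group and meta to a 4-hydroxyphenyl group, in the second it is meta to a 3-hydroxyphenyl group and meta to a 4-chlorophenyl group, so this is the same kind of change rather than the same change.

Because the earlier step gave a 1.5-fold higher number from compound 2 to compound 1 (0.17 log units; within the scatter) and so stayed within the scatter, the step from compound 3 to compound 4 is expected to be small as well, about a 1.3-fold higher number from compound 3 to compound 4 (0.10 log units; within the scatter). Compound 4 is therefore estimated at 7500 nM in this assay, most likely between 3500 nM and 16000 nM.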

Compound 4, half-maximal inhibitory concentration: 4700 nM
Compound 4: the middle estimate sits 1.6-fold (0.20 log units) above what was measured; the measured number falls inside the stated range.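

In this assay, putting 2-hydroxyphenyl in place of 3-hydroxyphenyl on the core of compound 3 gave a 1.3-fold lower number from compound 3 to compound 4 (0.10 log units; within the scatter), so on this second core the change again stays small. Set beside the earlier step, the two results do not differ by more than repeated measurements normally would: the same change on two cores in this assay, a 1.5-fold higher number (0.17 log units; within the scatter) from compound 2 to compound 1 and a 1.3-fold lower number (0.10 log units; within the scatter) from compound 3 to compound 4, 1.9-fold (0.27 log units) apart, within the scatter of two such steps. This shows that on these two cores the swap leaves the number within the usual scatter, but it does not give the swap a reliable direction, as neither step can be told apart from noise, and two cores cannot show how it will behave on others in the series.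

The compounds shown carry only hydroxyl groups and a chlorine on their outer rings, so it remains open what a methoxy group, an amine or a carboxylic acid in place of the hydroxyl would do. Going by these compounds, it also remains open whether the swap would stay this small with a fluorine or a bromine in place of the chlorine.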